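From compound 1 to compound 4: a smaller ether side chain

The source may hold more compounds than are shown below. What is called first, only, known or untested is meant among the compounds shown, and "the series" means these compounds.

The measured compounds:
compound 1 `Cc1nn(-c2ncnc3nc[nH]c23)c2c1C(OCc1cc(F)cc3c1OCOC3)CC(=O)N2`, 1.5 nM
compound 3 `Cc1nn(-c2ncnc3nc[nH]c23)c2c1C(OCc1ccccc1F)CC(=O)N2`, 4 nM
compound 2 `Cc1nn(-c2ncnc3nc[nH]c23)c2c1C(c1ccc(OC(C)C)cc1)CC(=O)N2`, 18 nM

In a functional assay on HEK293 cells for agonist activity at G-protein coupled receptor 39 (Homo sapiens), read by scintillation proximity assay and inositol phosphate accumulation, with a stated time of 75 min, in the presence of a further agent that is not named here (a higher number here means that more compound is needed for the effect, a lower number that less compound is needed), compound 1 stands lowest of the three numbers. Its nearest neighbour is compound 3, reached by a 2.7-fold higher number from compound 1 to compound 3 (0.43 log units; beyond the scatter). Going by the values given here, compound 2, which gives 18 nM, lies furthest from compound 1; no single step links these two. The other step, a 4.5-fold lower number from compound 2 to compound 3 (0.65 log units; beyond the scatter), shows the ether-linked aromatic group giving the lower number.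

Compound 4 `Cc1nn(-c2ncnc3nc[nH]c23)c2c1C(OCCn1cccn1)CC(=O)N2` has not yet been measured. Relative to compound 1 the change is a group of 6 heavy atoms (4 carbon, 2 nitrogen; one five-membered aromatic ring with 2 hetero atoms) in place of a group of 11 heavy atoms (8 carbon, 2 oxygen, 1 fluorine; one six-membered non-aromatic ring with 2 hetero atoms, one six-membered aromatic ring of carbon only), on a saturated chain carbon bound to an oxygen on a saturated carbon. The step from compound 1 to compound 3 bears most directly on this, since it too removes the larger group at the same place and raises the number modestly. The entering group here is smaller still, so a somewhat larger rise than that one is expected: a 10-fold higher number from compound 1 to compound 4 (1.00 log units; beyond the scatter). Compound 4 is therefore estimated at 15 nM, in the range 4 nM to 60 nM.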

Compound 4, half-maximal effective concentration: 16 nM
Estimate against measurement, compound 4: 1.1-fold (0.03 log units) below, and the stated range covers the measured number.
By their numbers in this assay, from the lowest: compound 1; then compound 3; then compounds 4 and 2 (each within the scatter of the next).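

In this assay, (1H-pyrazol-1-yl)methyl on this chain carbon gives a higher number than either group with a six-membered aromatic carbon ring (an 11-fold higher number from compound 1 to compound 4 (1.03 log units; beyond the scatter); a 4.0-fold higher number from compound 3 to compound 4 (0.60 log units; beyond the scatter)), so the ether link alone does not hold the number low. Against 4-isopropoxyphenyl on the saturated ring carbon, 2-(1H-pyrazol-1-yl)ethoxy shows no difference beyond the scatter (a 1.1-fold lower number from compound 2 to compound 4 (0.05 log units; within the scatter)). Nothing available gives a cause for these steps. Going by these compounds, whether a longer chain carrying the pyrazole, or an amine in its place, would move the number remains open.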